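The source may hold more compounds than are shown below. What is called first, only, known or untested is meant among the compounds shown, and "the series" means these compounds.

compound 1 `Cc1cc(C)cc(/C=C(\C(=O)c2ccc(Br)cc2)S(=O)(=O)Cc2ccc(F)cc2)c1`: 10000 nM
compound 2 `CN(C)c1ccc(/C=C(/SCc2ccc(Br)cc2)C(=O)c2ccc(C(=O)O)cc2)cc1`: 50000 nM
compound 3 `O=C(O)c1ccc(C(=O)/C(=C\c2ccccc2F)SCc2ccc(Br)cc2)cc1`: 10000 nM

In a functional assay on DU-145 cells (Homo sapiens) for inhibition, read by trypan blue exclusion, with a stated time of 96 h (on this read-out higher numbers stand for weaker inhibition of growth and lower numbers for stronger inhibition of growth), compound 1 gives 10000 nM, level with compound 3 at 10000 nM, while compound 2 reads 50000 nM. Compound 4 `COc1ccccc1/C=C(\C(=O)c1ccc(Br)cc1)S(=O)(=O)Cc1ccc(F)cc1` differs from compound 1 by one change: 2-methoxyphenyl in place of 3,5-dimethylphenyl on a double-bonded chain carbon bound to a double-bonded chain carbon. Among the compounds with values here, only one measured step bears on this place: a 5.0-fold lower number from compound 2 to compound 3 (0.70 log units; beyond the scatter). That step is modest, though beyond the scatter, but it comes from a different remainder of the molecule and involves neither group exchanged here. It therefore gives weak guidance, and no step beyond the scatter is expected. The expected step is a 1.3-fold lower number from compound 1 to compound 4 (0.10 log units; within the scatter). For compound 4 the estimated value is 8000 nM, with an expected range of 2500 nM to 25000 nM.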

Compound 4, concentration for 50% growth inhibition: 25000 nM
The estimate for compound 4 lay 3.1-fold (0.49 log units) below the measured number; measured number inside the range.
By their numbers in this assay, from the lowest: compounds 1 and 3 (each within the scatter of the next); then compounds 4 and 2 (each within the scatter of the next).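

In this assay 2-methoxyphenyl in place of 3,5-dimethylphenyl gives a 2.5-fold higher number from compound 1 to compound 4 (0.40 log units; beyond the scatter) and so shows that the group on this double-bonded chain carbon also counts on this remainder of the molecule, as it did on the other remainder (a 5.0-fold lower number from compound 2 to compound 3 (0.70 log units; beyond the scatter)). The two exchanged groups have equal heavy-atom counts, and the entering group adds an oxygen and a hydrogen-bond acceptor. No measured evidence accounts for this step.

This single exchange cannot separate the effect of adding the methoxy group from that of losing the two methyl groups. From the compounds shown here alone, how an amine or a carboxylic acid on this ring would read on the same remainder stays open.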